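A few compounds are considered here, and "the series" means these few. Any claim that something is new, unique, unknown or untested is made for them only; others in the source may bear on it.

Compound 1, `CC1=C(C(=O)OC(C)(C)C)C(c2ccsc2)NC(=O)N1`, in an assay on membranes from CHO cells for displacement of a labelled ligand from adenosine receptor A1 (Homo sapiens), read by scintillation counting, with a stated time of 60 min, tested at 1 uM (on this read-out higher numbers stand for more inhibition at the one concentration tested (going by the name of the read-out) and lower numbers for less inhibition), gives 15%.
Compound 2, `CC1=C(C(=O)CC(C)C)C(c2ccsc2)NC(=O)N1`, gives 37%.
Compound 3, `CCNC(=O)C1=C(C)NC(=O)NC1c1ccsc1`, gives 3%.

Compound 3 stands lowest of the three measured numbers. Its nearest neighbour is compound 1, where the step of a number 12 percentage points lower from compound 1 to compound 3 (beyond the scatter) is beyond the scatter, and the furthest is compound 2, with a number 34 percentage points lower from compound 2 to compound 3 (beyond the scatter). Both of these steps end in compound 3 and both change the group on the carbonyl carbon, so they bear directly on the next move. Compound 4, `CCSC(=O)C1=C(C)NC(=O)NC1c1ccsc1`, differs from compound 3 in exactly that place: ethylsulfanyl in place of ethylamino on a carbonyl carbon. Every measured replacement of ethylamino by another group on this carbonyl carbon, read in reverse, has given more inhibition, and the smaller of the two, a number 12 percentage points lower from compound 1 to compound 3 (beyond the scatter), involved an oxygen-linked group that ethylsulfanyl most resembles in the words of the difference. The account therefore expects compound 4 to rise above compound 3 in this assay by a modest step, a number 15 percentage points higher from compound 3 to compound 4 (beyond the scatter), rather than reach the level of compound 2. Compound 4 is estimated at 18%, with a range from 5% to 35%.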

Compound 4, a percentage reported as inhibition, at one concentration (the size of the read-out at that concentration, not a potency): 11%
Beside the measured number, compound 4's estimate is 7 percentage points above it; the range from low to high includes it.
By their numbers in this assay, from the lowest: compounds 3, 4 and 1 (each within the scatter of the next, the first and the last beyond it); then compound 2.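

With ethylsulfanyl on the carbonyl carbon, this assay does not separate the thioester from the amide, at a number 8 percentage points higher from compound 3 to compound 4 (within the scatter), so exchanging the nitrogen and its amide hydrogen for sulfur leaves no readable change. Nor does it separate the thioester from the tert-butoxy ester, at a number 4 percentage points lower from compound 1 to compound 4 (within the scatter), which places compound 4 within the scatter of both compound 3 and compound 1, even though those two lie beyond the scatter of each other; isobutyl stands apart, at a number 26 percentage points lower from compound 2 to compound 4 (beyond the scatter), so among these four groups the only one joined to the carbonyl carbon through carbon is also the one that gives a number beyond the scatter of all the others. Nothing in the material shown explains these differences.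

On these data alone, whether the level of compound 2 goes with a carbon link as such or with the branched isobutyl chain stays open, and an ethyl group or a straight butyl chain on the carbonyl carbon would bear on that. Also open, as far as these compounds go, is where ethoxy, the oxygen counterpart of ethylsulfanyl, would fall in this assay.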